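Acyl variation on a trimethoxyphenyl amide series

The source may hold more compounds than are shown below. What is called first, only, known or untested is meant among the compounds shown, and "the series" means these compounds.

Measured compounds in a functional assay on KYSE-450 cells (Homo sapiens) for inhibition, read by MTT assay, with a stated time of 48 h; on this read-out higher numbers stand for weaker inhibition and lower numbers for stronger inhibition:
compound 1 `COCC(=O)N(Cc1ccc(OC)c(O)c1)c1cc(OC)c(OC)c(OC)c1`: 460 nM
compound 2 `COc1ccc(CN(C(C)=O)c2cc(OC)c(OC)c(OC)c2)cc1O`: 160 nM
compound 3 `C=C(C)C(=O)N(Cc1ccc(OC)c(O)c1)c1cc(OC)c(OC)c(OC)c1`: 200 nM

Among the three measured compounds, compound 1 gives the highest number in this assay; the nearest is compound 3 a 2.3-fold lower number from compound 1 to compound 3 (0.36 log units; beyond the scatter), and the furthest is compound 2 a 2.9-fold lower number from compound 1 to compound 2 (0.46 log units; beyond the scatter). Compound 4 `C/C=C/C(=O)N(Cc1ccc(OC)c(O)c1)c1cc(OC)c(OC)c(OC)c1` has not yet been measured. It differs from compound 1 in one place: prop-1-en-1-yl in place of methoxymethyl on a carbonyl carbon.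

For the measured compounds named here, two measured steps bear on this change, since each also removes the methoxymethyl from the carbonyl carbon: a 2.9-fold lower number from compound 1 to compound 2 (0.46 log units; beyond the scatter) and a 2.3-fold lower number from compound 1 to compound 3 (0.36 log units; beyond the scatter). Between compound 2 and compound 3 the step is a 1.3-fold higher number from compound 2 to compound 3 (0.10 log units; within the scatter), so the two replacements for methoxymethyl gave similar numbers. The prop-1-en-1-yl group, like the 1-methylethenyl of compound 3, places a double bond on the carbonyl carbon, so a step of similar size and direction is expected. Compound 4 is therefore estimated at 200 nM, with a range from 100 nM to 420 nM, which would be a step of a 2.3-fold lower number from compound 1 to compound 4 (0.36 log units; beyond the scatter).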

Compound 4, half-maximal inhibitory concentration: 67 nM
Beside the measured number, compound 4's estimate is 3.0-fold (0.47 log units) above it; measured number below the stated range.
By their numbers in this assay, from the lowest: compound 4; then compounds 2 and 3 (each within the scatter of the next); then compound 1.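

In this assay, for the compounds shown here, the carbonyl carbon turns out to be more sensitive to the choice of group than the earlier compounds suggested, with the replacement of methoxymethyl by prop-1-en-1-yl giving the largest step from compound 1 so far (a 6.9-fold lower number from compound 1 to compound 4 (0.84 log units; beyond the scatter)). Having a double bond in the group on this carbonyl carbon does not by itself fix the number, as prop-1-en-1-yl and 1-methylethenyl give clearly different results (a 3.0-fold lower number from compound 3 to compound 4 (0.47 log units; beyond the scatter)). Prop-1-en-1-yl also separates from the simple methyl group (a 2.4-fold lower number from compound 2 to compound 4 (0.38 log units; beyond the scatter)), whereas 1-methylethenyl did not. On these data alone, it remains open whether a longer chain, a cyclopropyl ring or a dimethylamino-substituted propenyl group on this carbonyl carbon would extend or reverse this step. Nothing given here accounts for the difference between these groups.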